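This account rests on a few compounds, and the source may have more. Where it says the series, first, only, none or still open, it means among the compounds named here.

Measured so far in a functional assay for antagonist activity at transient receptor potential cation channel subfamily V member 1 (Rattus norvegicus); on this read-out lower numbers stand for stronger inhibition and higher numbers for weaker inhibition:

compound 1, `CC(C)(C)c1ccc(NC(=O)c2ccc(-c3ccccn3)cc2)cc1`: 8 nM
compound 2, `CCCNc1cccnc1-c1ccc(C(=O)Nc2ccc(C(C)(C)C)cc2)cc1`: 37 nM
compound 3, `CC(C)(C)c1ccc(NC(=O)c2ccc(-c3ncccc3NS(C)(=O)=O)cc2)cc1`: 35 nM

All three share one core and differ only in what sits on the ring attached to it. Compound 1 carries hydrogen there and gives the lowest number of the three. Putting a propylamino group in its place gives a 4.6-fold higher number from compound 1 to compound 2 (0.67 log units; beyond the scatter), and putting a methanesulfonamido group there gives a 4.4-fold higher number from compound 1 to compound 3 (0.64 log units; beyond the scatter). Compound 3 therefore sits clearly above compound 1, while the remaining pair shows a 1.1-fold lower number from compound 2 to compound 3 (0.02 log units; within the scatter), so compounds 2 and 3 cannot be told apart on these numbers.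

Compound 4, `CC(C)(C)c1ccc(NC(=O)c2ccc(-c3ncccc3NS(=O)(=O)c3ccccc3)cc2)cc1`, keeps the sulfonamide of compound 3 and changes only the group on its sulfur: phenyl in place of methyl on a sulfonyl sulfur. Among the compounds with values here, no measured step alters this sulfonyl substituent, so the only guide is how little the step from compound 2 to compound 3 mattered, where a different group on that same nitrogen left the number unchanged within the scatter. On that basis the change in this assay from compound 3 to compound 4 is expected to be small, a 1.4-fold higher number from compound 3 to compound 4 (0.15 log units; within the scatter), with no clear direction. Compound 4 is thus estimated at 50 nM in this assay, with a range from 15 nM to 170 nM.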

Compound 4, half-maximal inhibitory concentration: 166 nM
Beside the measured number, compound 4's estimate is 3.3-fold (0.52 log units) below it; low and high end bracket the measured number.
By their numbers in this assay, from the lowest: compound 1; then compounds 3 and 2 (each within the scatter of the next); then compound 4.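

The group on the sulfonyl sulfur matters in this assay: phenyl in place of methyl moves the number beyond the scatter (a 4.7-fold higher number from compound 3 to compound 4 (0.68 log units; beyond the scatter)), whereas exchanging propyl for methylsulfonyl on that same nitrogen had left it within the scatter. Phenylsulfonyl in place of propyl on that nitrogen also gives a change beyond the scatter (a 4.5-fold higher number from compound 2 to compound 4 (0.65 log units; beyond the scatter)), and (phenylsulfonyl)amino in place of hydrogen gives the largest step among these four compounds (a 21-fold higher number from compound 1 to compound 4 (1.32 log units; beyond the scatter)), so all three groups shown on this aromatic carbon give higher numbers than hydrogen, with (phenylsulfonyl)amino giving the highest. Nothing available explains why adding the phenyl ring weakens inhibition here.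

The compounds shown leave open whether this rise is particular to phenyl or would also appear with other groups on the sulfur, such as ethyl, benzyl or a phenyl ring carrying a fluorine or a methoxy group. They also leave open how the number would respond to an acetyl group in place of the sulfonyl on that nitrogen, or to a free amine on the aromatic carbon.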